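The source may hold more compounds than are shown below. What is called first, only, known or untested is meant among the compounds shown, and "the series" means these compounds.

Compound 1 `CCN1CCN(C(=O)/C=C/C=C/[C@H](O)Cc2ccc(OC)c(OC)c2)CC1` belongs to a group of three close relatives that share one core and differ only in the group carried on the amide carbonyl. In a functional assay on HeLa cells (Homo sapiens) for antiproliferative activity, read by sulforhodamine B assay, with a stated time of 48 h (on this read-out lower numbers stand for stronger inhibition and higher numbers for weaker inhibition), compound 1 gives 11700 nM. Compound 2 `COc1ccc(C[C@@H](O)/C=C/C=C/C(=O)N2CCN(c3ncccn3)CC2)cc1OC` gives 12600 nM, and compound 3 `COc1ccc(C[C@@H](O)/C=C/C=C/C(=O)N2CCN(C(c3ccccc3)c3ccccc3)CC2)cc1OC` gives 10500 nM. Among these three numbers compound 1 stands second highest; its step to compound 2, a 1.1-fold higher number from compound 1 to compound 2 (0.03 log units; within the scatter), and its gap to compound 3 both lie within the scatter. The unmeasured compound 4 `COc1ccc(C[C@@H](O)/C=C/C=C/C(=O)N2CCCCC2)cc1OC` differs from compound 1 at the same end of the molecule: piperidin-1-yl in place of 4-ethylpiperazin-1-yl on a carbonyl carbon. Among the compounds with values here, the one measured step that bears on this place, a 1.1-fold higher number from compound 1 to compound 2 (0.03 log units; within the scatter), shows that exchanging the group on the ring nitrogen gave a step within the scatter, and compound 3 shows the same picture with a larger group there. Within the data shown here, the change to compound 4 goes further, putting a ring with a single hetero atom in place of one with two, which no measured pair covers, so the expectation is a step of a 1.1-fold lower number from compound 1 to compound 4 (0.03 log units; within the scatter), no larger than the scatter. Compound 4 is therefore estimated at 11000 nM, within 4000 nM to 30000 nM.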

Compound 4, half-maximal inhibitory concentration: 14100 nM
The estimate for compound 4 lay 1.3-fold (0.11 log units) below the measured number; the measured number falls inside the stated range.
By their numbers in this assay, from the lowest: compounds 3, 1, 2 and 4 (each within the scatter of the next).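

In this assay, within the data shown here, the earlier compounds changed only the group on the outer ring nitrogen, whereas compound 4 removes that nitrogen and its ethyl group together, with a 1.2-fold higher number from compound 1 to compound 4 (0.08 log units; within the scatter). With piperidin-1-yl on the carbonyl carbon, the ring has one hetero atom rather than two, and the step still does not exceed the scatter, so the second ring nitrogen is not needed to keep the number in this range. No measurement shown gives a reason for this flat picture.

On these data alone, it remains open whether a morpholin-4-yl ring or an open-chain dimethylamino group on the carbonyl carbon would also fit this picture. The compounds shown also vary only this end of the molecule, leaving open what changes elsewhere on the shared core would do.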